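Swapping the aryl end for a dimethylaminomethyl-furan

This account rests on a few compounds, and the source may have more. Where it says the series, first, only, none or still open, it means among the compounds named here.

Of the compounds shown here, three sharing one core have been measured in a functional assay on Sf9 cells for antagonist activity at histamine H2 receptor (Homo sapiens), with stated times of 2 min and 20 min; on this read-out lower numbers stand for lower potency and higher numbers for higher potency (the scale is a negative logarithm). Compound 1 `CC(CC(=O)/N=C(\N)NCCCc1ccccc1)c1ccccc1` gives 5.89; compound 2 `CC(CC(=O)/N=C(\N)NCCCc1cccnc1)c1ccccc1` gives 5.27; compound 3 `CC(CC(=O)/N=C(\N)NCCCc1ccncc1)c1ccccc1` gives 5.54, the second highest of the three. The steps seen so far, a number 0.62 log units lower from compound 1 to compound 2 (beyond the scatter) and a number 0.35 log units lower from compound 1 to compound 3 (beyond the scatter), were modest, and a number 0.27 log units higher from compound 2 to compound 3 (within the scatter) stayed inside the scatter. Compound 4 `CC(CC(=O)/N=C(\N)NCCCc1ccc(CN(C)C)o1)c1ccccc1` carries a different change: 5-((dimethylamino)methyl)furan-2-yl in place of pyridin-4-yl on a saturated chain carbon, three bonds along the chain from an amine nitrogen. Going by the values given here, no measured step replaces an aromatic ring with a five-membered ring bearing a dimethylaminomethyl group, so the earlier steps only show that this end tolerates modest change. The step of a number 0.86 log units higher from compound 3 to compound 4 (beyond the scatter) is an estimate, and compound 4 is expected at 6.4, within 5.6 to 7.2.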

Compound 4, negative logarithm of the antagonist equilibrium constant: 6.52
Beside the measured number, compound 4's estimate is 0.12 log units below it; measured number inside the range.
By their numbers in this assay, from the lowest: compounds 2 and 3 (each within the scatter of the next); then compound 1; then compound 4.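

The 5-((dimethylamino)methyl)furan-2-yl group raises the number at this position, with a number 0.98 log units higher from compound 3 to compound 4 (beyond the scatter) and a number 1.25 log units higher from compound 2 to compound 4 (beyond the scatter). Both pyridine rings had given lower numbers than phenyl, whereas this group gives a number 0.63 log units higher from compound 1 to compound 4 (beyond the scatter), so this end can gain potency as well as lose it. Nothing available explains this gain. The furan ring and the dimethylaminomethyl group enter together, and the compounds shown leave open which of them matters. A plain furan-2-yl, or a phenyl carrying a dimethylaminomethyl group, would separate the two.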